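The source may report more compounds than this note shows. Statements on the series, on what has been measured and on what is new or still open speak of the compounds shown alone.

Four compounds share one core and differ from one another only in two side groups. Compound 1 `C[C@H](Nc1c(C(N)=O)nnc2ccc(-c3ccc(OCCCN(C)C)nc3)cc12)C1CCOCC1` was tested in an ADME assay on cells (Hepatocyte, Rattus norvegicus) for metabolic stability, read by HPLC, with a stated time of 30 min, tested at 1 uM (a lower number here means slower removal, a higher number faster removal of the compound), and there compound 1 gives 3.4 uL/min. Compound 2 `C[C@H](Nc1c(C(N)=O)nnc2ccc(-c3ccc(OCCCN(C)C)nc3)cc12)c1ccn(C)n1` carries 1-methyl-1H-pyrazol-3-yl in place of oxan-4-yl on a saturated chain carbon bound to a nitrogen on an aromatic ring and a saturated chain carbon, and in this assay compound 2 gives 7 uL/min, which is a 2.1-fold higher number from compound 1 to compound 2 (0.31 log units; beyond the scatter). Compound 3 `C[C@H](Nc1c(C(N)=O)nnc2ccc(-c3ccc(OCCCN4CCCC4)nc3)cc12)C1CCOCC1` differs from compound 1 at the other end of the molecule, by pyrrolidin-1-yl in place of dimethylamino on a saturated chain carbon, three bonds along the chain from an oxygen on an aromatic ring, and in this assay compound 3 gives 1.9 uL/min, which is a 1.8-fold lower number from compound 1 to compound 3 (0.25 log units; within the scatter). Compound 4 `C[C@H](Nc1c(C(N)=O)nnc2ccc(-c3ccc(OCCCN4CCCC4)nc3)cc12)c1ccn(C)n1` has not yet been measured. It differs from compound 3 by 1-methyl-1H-pyrazol-3-yl in place of oxan-4-yl on a saturated chain carbon bound to a nitrogen on an aromatic ring and a saturated chain carbon, and since the place is worded the same in both pairs, this is the same change that was made from compound 1 to compound 2; the only difference between the two pairs is that their cores differ in the way just described for compound 1 and compound 3. If the earlier step carries over, compound 4 is expected to lie a 2.1-fold higher number from compound 3 to compound 4 (0.32 log units; beyond the scatter) from compound 3 because a 2.1-fold higher number from compound 1 to compound 2 (0.31 log units; beyond the scatter) was seen for the same change. On that basis compound 4 is expected to give about 4 uL/min in this assay, with a likely range from 2.2 uL/min to 7.5 uL/min.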

Compound 4, intrinsic clearance in a liver preparation (reported as CLH), per the amount of preparation that the assay uses: 4.6 uL/min
Compound 4: middle estimate off by 1.2-fold (0.06 log units), on the low side; measured number inside the range.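

In this assay the new step for putting 1-methyl-1H-pyrazol-3-yl in place of oxan-4-yl is a 2.4-fold higher number from compound 3 to compound 4 (0.38 log units; beyond the scatter) and it agrees with the step seen earlier for the same change, so on these two cores the change carries over with much the same size: the same change on two cores in this assay, a 2.1-fold higher number (0.31 log units; beyond the scatter) from compound 1 to compound 2 and a 2.4-fold higher number (0.38 log units; beyond the scatter) from compound 3 to compound 4, 1.2-fold (0.07 log units) apart, within the scatter of two such steps. The change at the other end of the molecule, pyrrolidin-1-yl in place of dimethylamino, now reads a 1.5-fold lower number from compound 2 to compound 4 (0.18 log units; within the scatter) and this step also agrees with its earlier counterpart, though neither step stands out from the usual scatter of the measurement, so the two end groups cannot be told apart here: the same change on two cores in this assay, a 1.8-fold lower number (0.25 log units; within the scatter) from compound 1 to compound 3 and a 1.5-fold lower number (0.18 log units; within the scatter) from compound 2 to compound 4, 1.2-fold (0.07 log units) apart, within the scatter of two such steps. This is one comparison on just two closely related cores in a single assay, so it shows that the two changes behaved independently here but does not show that they would do so on a different core, and it gives no reason for the size of either step.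

The compounds shown leave open how a piperidine or morpholine ring would behave at the end of the chain, and whether a longer or shorter chain would alter the picture. They also leave open whether a phenyl ring or a differently attached pyrazole, in place of oxan-4-yl, would give a step of similar size.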